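This account rests on a few compounds, and the source may have more. Where it says the series, first, only, none or still open, it means among the compounds named here.

For the measured compounds named here, compound 3 `O=C1CSC(=O)N1C[C@H]1CN(c2ccc(-n3cc(-c4ccccn4)cn3)c(F)c2)C(=O)O1` is the one member of this small set with a number in an ADME assay on HEK293-A cells (Homo sapiens) for cytotoxicity, read by MTT assay, with a stated time of 48 h (on this read-out lower numbers stand for stronger inhibition and higher numbers for weaker inhibition), where compound 3 gives 283 ug/mL. In this assay compound 1 `CN(CCC#N)C[C@H]1CN(c2ccc(-n3cc(-c4ccccn4)cn3)c(F)c2)C(=O)O1` gives only a limit, > 400 ug/mL. Compound 2 `O=C1O[C@@H](CN2CCC(O)CC2)CN1c1ccc(-n2cc(-c3ccccn3)cn2)c(F)c1` likewise gives only a limit, > 400 ug/mL. The set is dominated by the limit of > 400 ug/mL in this assay, at which 2 of the 3 values shown sit. Compound 4 `CC(=O)OC[C@H]1CN(c2ccc(-n3cc(-c4ccccn4)cn3)c(F)c2)C(=O)O1` differs from compound 3 in one place: acetoxy in place of 2,4-dioxo-1,3-thiazolidin-3-yl on a saturated chain carbon bound to a saturated ring carbon. The measured steps that touch this position read an at least 1.4-fold lower number from compound 1 to compound 3 (0.15 log units; that floor lies within the scatter) and an at least 1.4-fold lower number from compound 2 to compound 3 (0.15 log units; that floor lies within the scatter), both floors lying within the scatter. On that basis the number for compound 4 is expected to drift back toward the limit, by about a 1.2-fold higher number from compound 3 to compound 4 (0.09 log units; within the scatter). Compound 4 is estimated at 350 ug/mL, with a range from 200 ug/mL to 600 ug/mL.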

Compound 4, half-maximal inhibitory concentration: > 400 ug/mL
Compound 4: a limit, no number; the forecaster's own chance of this, stated with the estimate: 50%; middle value at least 1.1-fold (0.05 log units) away from the limit.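

In this assay, putting acetoxy, which has no ring, in place of 2,4-dioxo-1,3-thiazolidin-3-yl gives an at least 1.4-fold higher number from compound 3 to compound 4 (0.15 log units; that floor lies within the scatter). For the compounds shown here, a non-basic ester therefore reads as a limit too, just as the two amine-bearing groups of compound 1 and compound 2 do, and compound 3 remains the only compound with a number. The steps to compound 4 from compound 1 and compound 2 join two limits and cannot be read, and one limit now dominates the set: the limit of > 400 ug/mL in this assay, at which 3 of the 4 values shown sit.

From the compounds shown here alone, whether the five-membered ring of compound 3 truly separates it from the others stays open, as its step remains within the scatter. Also open, going by these compounds, is how a carboxylic acid or a primary amine on this saturated chain carbon would read.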